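Exchange of an Aryl Group on an Inactive Shared Core

The source may hold more compounds than are shown below. What is called first, only, known or untested is meant among the compounds shown, and "the series" means these compounds.

In a functional assay on MCF7 cells (Homo sapiens) for antiproliferative activity (a lower number here means a stronger inhibitor, a higher number a weaker inhibitor), compound 1 `COc1ccc(-c2cn(-c3cc4ccc(O)c(C)c4oc3=O)nn2)cc1` gives > 100000 nM, a limit of the assay.
In this assay compound 2 `Cc1c(O)ccc2cc(-n3cc(-c4ccc(N(C)C)cc4)nn3)c(=O)oc12` gives > 100000 nM, a limit of the assay.
In this assay compound 3 `CC(=O)Oc1ccc2cc(-n3cc(-c4ccc(N(C)C)cc4)nn3)c(=O)oc2c1C` gives > 100000 nM, a limit of the assay.

Compound 3 therefore stands where every measured compound stands: at the limit of > 100000 nM in this assay, at which 3 of the 3 values shown sit. The two measured steps, a step that the two limits leave unreadable from compound 1 to compound 2 and a step that the two limits leave unreadable from compound 2 to compound 3, both run between limits, so neither tells how far any change moved the half-maximal inhibitory concentration.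

Compound 4 `CC(=O)Oc1ccc2cc(-n3cc(-c4c[nH]c5ccccc45)nn3)c(=O)oc2c1C` is the next compound to be measured. Its change from compound 3 is 1H-indol-3-yl in place of 4-(dimethylamino)phenyl on an aromatic carbon. Within the data shown here, no measured step bears readably on this exchange, and the shared core has so far given only limits. The expectation for compound 4 therefore rests on that record alone: the most likely outcome is estimated to be another limit, and the estimated step of a number no higher from compound 3 to compound 4 (the limit leaves the size open) is expected to be none that the data can read. The estimate for compound 4 in this assay is 100000 nM, with a range from 20000 nM to 300000 nM.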

Compound 4, half-maximal inhibitory concentration: 7450 nM
Estimate against measurement, compound 4: 13-fold (1.13 log units) above, and the stated range ends above it.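

In this assay, 1H-indol-3-yl in place of 4-(dimethylamino)phenyl on this aromatic carbon gives an at least 13-fold lower number from compound 3 to compound 4 (1.12 log units; beyond the scatter), the only step shown whose size can be read, and even that only as a bound. The shared core is therefore not inactive in every form, and the group at this place on the five-membered aromatic ring with 3 nitrogen can separate a limit from a measured value. The two groups have the same count of 9 heavy atoms but differ in ring type and hydrogen-bond donors, and compound 4 alone stands off the limit: the limit of > 100000 nM in this assay, at which 3 of the 4 values shown sit.

Among these compounds, the earlier steps cannot be read, so whether compound 4 needs the acetyl on its oxygen remains open. Also open, going by these compounds, is how a plain phenyl, or an aryl group carrying a carboxylic acid, would behave at this place.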